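The source may hold more compounds than are shown below. What is called first, only, known or untested is meant among the compounds shown, and "the series" means these compounds.

Working notes on the series. In a functional assay on MDA-MB-231 cells (Homo sapiens) for antiproliferative activity, read by MTT assay, with a stated time of 48 h (a higher number here means a weaker inhibitor, a lower number a stronger inhibitor), compound 1 (`C=CS(=O)(=O)N1CCN(c2ncnc3ccc(-c4ccccc4)cc23)CC1`) gives 47900 nM and compound 2 (`C=CS(=O)(=O)N1CCN(c2ncnc3sc(-c4ccc(OC)cc4)cc23)CC1`) gives 29900 nM as its number, two values within the scatter of each other. Compound 3 (`C=CS(=O)(=O)N1CCN(c2ncnc3sc(-c4ccc(N5CCN(C)CC5)cc4)cc23)CC1`) gives 7550 nM and lies clearly under compound 2. Compound 2 thus sits level with compound 1 at the upper end of this small set.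

Within the data shown here, the one measured step from compound 2 is a 4.0-fold lower number from compound 2 to compound 3 (0.60 log units; beyond the scatter) and counts as modest. It puts 4-methylpiperazin-1-yl in place of methoxy on an aromatic carbon.

Compound 4 (`C=CS(=O)(=O)N1CCN(c2ncnc3sc(-c4cccc5ccccc45)cc23)CC1`) has no number yet. Its change from compound 2 is naphthalen-1-yl in place of 4-methoxyphenyl on an aromatic carbon with naphthalen-1-yl in place of 4-methoxyphenyl on an aromatic carbon, next to the ring sulfur. The step to compound 3 bears on this only loosely, since there the methoxy alone goes, while here the whole 4-methoxyphenyl leaves. Among the measured compounds shown here, no measured compound carries naphthalen-1-yl, so the data favour neither direction, and a shift larger than the modest 4.0-fold lower number from compound 2 to compound 3 (0.60 log units; beyond the scatter) has no support.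

The expected step is a 1.2-fold lower number from compound 2 to compound 4 (0.06 log units; within the scatter) by this estimate, so no change beyond the scatter is expected in this assay for now. For compound 4 the estimated value is 26000 nM with an expected range of 11000 nM to 60000 nM at its ends.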

Compound 4, half-maximal inhibitory concentration: 23700 nM
Estimate against measurement, compound 4: 1.1-fold (0.04 log units) above; measured number inside the range.
By their numbers in this assay, from the lowest: compound 3; then compounds 4, 2 and 1 (each within the scatter of the next, the first and the last beyond it).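

At this position, on an aromatic carbon next to the ring sulfur, putting naphthalen-1-yl in place of the whole 4-methoxyphenyl gives a 1.3-fold lower number from compound 2 to compound 4 (0.10 log units; within the scatter) in this assay. A second six-membered aromatic ring of carbon only can therefore enter here, and the hydrogen-bond acceptor of the methoxy can leave, without a change this assay can resolve. Of the two steps measured at this position, only a 4.0-fold lower number from compound 2 to compound 3 (0.60 log units; beyond the scatter) lies beyond the scatter, so a change of the aromatic group alone has not yet moved the number, and no measurement available accounts for either step.

The compounds shown leave open whether the step to compound 3 is specific to 4-methylpiperazin-1-yl, or whether another amine such as morpholin-4-yl or dimethylamino, or a carboxylic acid, on the same phenyl ring would give a step of similar size. They also leave open whether 4-methylpiperazin-1-yl or another amine carried on naphthalen-1-yl would lower the number from the level of compound 4 in the same way.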